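Chloro in place of hydrogen on compound 2

The compounds below may be only part of what the source reports. "The series", "measured", "known", "first", "only" and "open" are said of these compounds alone.

Compound 1 `C/C(=N\O)c1ccc(NC(=O)Cn2nc(-c3ccc(Cl)cc3)nc2N)cc1`: 6.42%
Compound 2 `COc1ccc(-c2nc3sc(-c4ccccc4)cn3n2)cc1`: 21%
Compound 3 `COc1cc(-c2nc3sc(-c4ccccc4)cn3n2)cc(OC)c1OC`: 42%

These values come from a functional assay on RPMI-8226 cells (Homo sapiens) for inhibition, read by sulforhodamine B assay, with a stated time of 48 h, tested at 10 uM (on this read-out lower numbers stand for less inhibition of growth and higher numbers for more inhibition of growth at the one concentration tested), and are the only ones known so far. Compound 2 stands second of the three, above compound 1 and under compound 3, with both gaps beyond the scatter. Compound 4 `COc1ccc(-c2nc3sc(-c4ccc(Cl)cc4)cn3n2)cc1` keeps the structure of compound 2 but carries chloro in place of hydrogen on an aromatic carbon, turning phenyl into 4-chlorophenyl chloro in place of hydrogen on an aromatic carbon in the molecule. Within the data shown here, no measured pair shows this change, so the expectation rests on compound 2 at 21% alone. The expected step of a number 5 percentage points higher from compound 2 to compound 4 (within the scatter) is small, upward and within the scatter. For compound 4 the expected value is 26% with 10% to 45% as its estimated range.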

Compound 4, percent growth inhibition at one concentration: 55.1%
For compound 4 the middle estimate is 29.1 percentage points below the measured one, outside the stated range (above it).
By their numbers in this assay, from the lowest: compound 1; then compound 2; then compound 3; then compound 4.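

In this assay the change from phenyl to 4-chlorophenyl gives a number 34.1 percentage points higher from compound 2 to compound 4 (beyond the scatter), the first single-place change seen in this series. It shows that this aromatic carbon, para to a large group, is not indifferent to substitution, as one chlorine atom in place of hydrogen moves growth inhibition well past the scatter. No measurement at hand accounts for the size of this step.

The compounds shown leave open whether fluoro, bromo or an amine at this carbon would do the same. They also leave open whether chloro here would give a similar step on compound 3 .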